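Halogen swaps on the aryl ring of three measured analogues

A few compounds are considered here, and "the series" means these few. Any claim that something is new, unique, unknown or untested is made for them only; others in the source may bear on it.

Compound 1 `Nc1nc(N)nc(-c2cc(F)ccc2Cl)n1` gives 78% in a functional assay on the whole organism with Rattus norvegicus as the target, at a dose of 20 mg/kg by the intraperitoneal route; a lower number here means less inhibition, a higher number more inhibition at the dose given (going by the name of the read-out). Compound 2 `Nc1nc(N)nc(-c2cc(Br)ccc2Cl)n1` gives 86% in this assay, and compound 3 `Nc1nc(N)nc(-c2cc(F)ccc2Br)n1` gives 78%. The change bromo in place of fluoro on an aromatic carbon made a number 8 percentage points higher from compound 1 to compound 2 (within the scatter). The change bromo in place of chloro on an aromatic carbon made no change at the digits printed from compound 1 to compound 3 (within the scatter), so the two cores are set apart by that one difference only, and compound 3 stands level with compound 1 at the digits printed, the two together the lowest of the three numbers.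

Compound 4 `Nc1nc(N)nc(-c2cc(Br)ccc2Br)n1` is not yet measured. It differs from compound 3 by bromo in place of fluoro on an aromatic carbon. Within the data shown here, this is the same kind of change as the one from compound 1 to compound 2, but not the same: there the place is para to a chloro group, here it is para to a bromo group.

A step of about the same size is expected, a number 7 percentage points higher from compound 3 to compound 4 (within the scatter), because the same kind of change gave a number 8 percentage points higher from compound 1 to compound 2 (within the scatter). On that basis compound 4 is estimated at 85% in this assay, with the expected range running from 72% to 94%.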

Compound 4, a percentage reported as inhibition, in the whole organism at one dose (the size of the read-out at that dose, not a potency): 43%
For compound 4 the middle estimate is 42 percentage points above the measured one, outside the stated range (below it).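

In this assay, the change to bromo in place of fluoro does not carry from one core to the other: the same change on two cores in this assay, a number 8 percentage points higher (within the scatter) from compound 1 to compound 2 and a number 35 percentage points lower (beyond the scatter) from compound 3 to compound 4, 43 percentage points apart, beyond the scatter of two such steps

The change to bromo in place of chloro behaves the same way: the same change on two cores in this assay, no change at the digits printed (within the scatter) from compound 1 to compound 3 and a number 43 percentage points lower (beyond the scatter) from compound 2 to compound 4, 43 percentage points apart, beyond the scatter of two such steps

The two steps into the analogue carrying two bromo groups, a number 35 percentage points lower from compound 3 to compound 4 (beyond the scatter) and a number 43 percentage points lower from compound 2 to compound 4 (beyond the scatter), show that in these compounds the effect of each swap depends on the halogen already at the other place, so neither step can be used as a fixed increment in this series; they do not show why the number falls, and with one dose and one pair per change they do not show how far this holds beyond these four compounds.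

As far as these compounds go, whether the fall is tied to bromo at both places or would also follow from a trifluoromethyl, methoxy or nitrile group at either place remains open. Also open, from the compounds shown here alone, is whether the gap seen at this one dose would persist across a range of doses.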